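Flavone side-chain series: from compound 3 to compound 4

The source may hold more compounds than are shown below. What is called first, only, known or untested is meant among the compounds shown, and "the series" means these compounds.

Measured so far:
Compound 1 `COc1cc(OC)c2c(=O)cc(-c3ccc(OCCBr)cc3)oc2c1` — "not active" (no number reported)
Compound 2 `COc1cc(OC)c2c(=O)cc(-c3ccc(OCCN4CCCC4=O)cc3)oc2c1` — 7%
Compound 3 `COc1cc(OC)c2c(=O)cc(-c3ccc(OCC(O)CN(C)C)cc3)oc2c1` — 42%
Compound 4 `COc1cc(OC)c2c(=O)cc(-c3ccc(Br)cc3)oc2c1` — not yet measured

In a functional assay (Homo sapiens) for antiproliferative activity, read by resazurin assay, with a stated time of 48 h, tested at 5 uM (on this read-out lower numbers stand for a weaker effect and higher numbers for a stronger effect at the one concentration tested), compound 3 gives 42%, the highest of the two numbers in hand; compound 2 gives 7%, and compound 1 is reported without a number. Among the measured compounds shown here, the single measured step, a number 35 percentage points higher from compound 2 to compound 3 (beyond the scatter), shows that the group on the saturated chain carbon bound to the ring oxygen drives the read-out in this small set.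

Compound 4 differs from compound 3 by bromo in place of 3-(dimethylamino)-2-hydroxypropoxy on an aromatic carbon. For the measured compounds named here, no measured step removes the oxygen-linked chain altogether, so the one step in hand bears on this change only indirectly: compound 3 alone carries a sizeable number, while compound 1 and compound 2, which keep a chain but lack the 2-(dimethylamino)-1-hydroxyethyl, are low or without number. A fall beyond the scatter is therefore expected for compound 4, a number 32 percentage points lower from compound 3 to compound 4 (beyond the scatter). A report of "not active" with no number, as for compound 1, cannot be ruled out. Compound 4 is estimated at 10%, with a range from 0% to 30%.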

Compound 4, a percentage reported as inhibition, at one concentration (the size of the read-out at that concentration, not a potency): 12%
The estimate for compound 4 lay 2 percentage points below the measured number, and the stated range covers the measured number.
By their numbers in this assay, from the lowest: compounds 2 and 4 (each within the scatter of the next); then compound 3.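

In this assay, among the compounds shown here, bromo on the aromatic carbon in place of the whole oxygen-linked chain gives a number 30 percentage points lower from compound 3 to compound 4 (beyond the scatter) as the first step that removes the chain rather than altering it. The comparison of bromo with 2-(2-oxopyrrolidin-1-yl)ethoxy gives a number 5 percentage points higher from compound 2 to compound 4 (within the scatter) and so shows that carrying a chain at this position does not by itself separate a compound from one bearing only bromo; among the compounds with numbers, only compound 3, with its 3-(dimethylamino)-2-hydroxypropoxy, stands clear of the others. No measured evidence on the origin of these differences is available.

Open, from the compounds shown here alone, is whether the dimethylamino nitrogen or the hydroxyl accounts for the number of compound 3, a question that a 3-(dimethylamino)propoxy chain and a 2,3-dihydroxypropoxy chain would address. Also open, going by these compounds, is how a cyclic amine such as piperidine or morpholine, or a longer chain, would read at this position.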